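Chloro in place of methyl on the benzyl ring

The compounds below may be only part of what the source reports. "The series", "measured", "known", "first", "only" and "open" are said of these compounds alone.

In a functional assay (spleen, spleen) for activation, with Mus musculus as the target (a higher number here means that more compound is needed for the effect, a lower number that less compound is needed), the two measured compounds stand as follows:
compound 1 `Cc1nc(N)c2nc(O)n(Cc3ccccc3)c2n1`, 1 uM
compound 2 `Cc1ccc(Cn2c(O)nc3c(N)ncnc32)cc1`, 10 uM

Compound 2 holds the higher of the two numbers in this assay; its nearest neighbour, compound 1, sits a full step lower, and the gap between them is beyond the scatter. Compound 3 `Nc1ncnc2c1nc(O)n2Cc1ccc(Cl)cc1` has not yet been measured. It differs from compound 2 in one place: chloro in place of methyl on an aromatic carbon. Going by the values given here, with no measured pair showing such a change, a step within the scatter is expected, in either direction or none. Compound 3 is therefore estimated at 10 uM, with a range of 3 uM to 30 uM, which would mean a step of no change at the digits printed from compound 2 to compound 3 (within the scatter).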

Compound 3, minimum effective concentration: 10 uM
Compound 3: middle estimate and measured number agree at the digits printed, and the stated range covers the measured number.
By their numbers in this assay, from the lowest: compound 1; then compounds 2 and 3 (each within the scatter of the next).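

In this assay, going by these compounds alone, chloro in place of methyl on an aromatic carbon, para to a large group, gives no change at the digits printed from compound 2 to compound 3 (within the scatter), the first step read between compounds that differ in one place. At this position, then, the two groups cannot be told apart in this assay. Nothing measured here says why they read alike.

On these data alone, whether an amine, a methoxy group or a carboxylic acid at this position would also leave the number in place remains open. So does whether chloro for methyl would give the same step on the core of compound 1.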